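A few compounds are considered here, and "the series" means these few. Any claim that something is new, unique, unknown or untested is made for them only; others in the source may bear on it.

Among the measured compounds shown here, in a functional assay on Caco-2 cells (Homo sapiens) for antiproliferative activity, read by MTT assay, with a stated time of 48 h (on this read-out higher numbers stand for weaker inhibition and lower numbers for stronger inhibition), compound 1 `CCn1c(C(=O)NCCN)ccc1C(CC)(CC)c1ccc(OCCC(O)(CC)CC)c(C)c1` gives 1740 nM, the only exact number so far. Compound 2 `CCn1c(C(=O)N(CCC#N)CCC#N)ccc1C(CC)(CC)c1ccc(OCCC(O)(CC)CC)c(C)c1` reads > 50000 nM, which is a limit of the assay. Compound 3 `CCC(C)C(NC(=O)c1ccc(C(CC)(CC)c2ccc(OCCC(O)(CC)CC)c(C)c2)n1CC)C(=O)OC` keeps the core of compound 1 and alters only the amide side chain: a group of 9 heavy atoms (7 carbon, 2 oxygen; no ring) in place of a group of 3 heavy atoms (2 carbon, 1 nitrogen; no ring), on an amide-type nitrogen. For the measured compounds named here, the one measured step that bears on this also put a larger group on the amide and gave an at least 28-fold higher number from compound 1 to compound 2 (1.45 log units; beyond the scatter), so weaker inhibition is expected here too, though perhaps by less. The expected change is an 8.6-fold higher number from compound 1 to compound 3 (0.94 log units; beyond the scatter). For compound 3 the estimated value is 15000 nM, with an expected range of 4000 nM to 50000 nM.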

Compound 3, half-maximal inhibitory concentration: > 50000 nM
Compound 3 ended at the assay's limit; the forecaster's own chance of this, stated with the estimate: 30%; middle value at least 3.3-fold (0.52 log units) from the limit.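

In this assay, replacing the 2-aminoethyl group on the amide-type nitrogen with a group of 9 heavy atoms that holds no nitrogen gives an at least 28-fold higher number from compound 1 to compound 3 (1.45 log units; beyond the scatter) as a limit, not an exact size. Compound 3 keeps the amide hydrogen that compound 2 lacks, so losing that hydrogen is not required for activity to fall this far. The step between compound 2 and compound 3 cannot be read, because both values are limits: the limit of > 50000 nM in this assay, at which 2 of the 3 values shown sit.

Still open, as far as these compounds go, is whether the amine of compound 1 is what matters. A longer amine such as 3-aminopropyl, or a carboxylic acid on the same nitrogen's side chain, would help to separate these possibilities.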